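Varying the aryl group on the sulfur: compound 4

A few compounds are considered here, and "the series" means these few. Any claim that something is new, unique, unknown or untested is made for them only; others in the source may bear on it.

Compound 1 `CCOC(=O)c1c(CSc2ccccc2OC)n(C)c2ccc(O)cc12`: in an assay on cells for inhibition of Polyunsaturated fatty acid 5-lipoxygenase (Homo sapiens), read by HPLC, with a stated time of 15 min (a higher number here means a weaker inhibitor, a lower number a stronger inhibitor), compound 1 gives 5100 nM.
Compound 2 `CCOC(=O)c1c(CSc2ccc(OC)cc2)n(C)c2ccc(O)cc12`: in this assay compound 2 gives 3100 nM.
Compound 3 `CCOC(=O)c1c(CSc2ccc(F)cc2F)n(C)c2ccc(O)cc12`: in this assay compound 3 gives 6800 nM.

Compound 3 has the highest of the three numbers in this assay. Its nearest neighbour is compound 1, at a 1.3-fold higher number from compound 1 to compound 3 (0.12 log units; within the scatter), a step within the scatter. The step of a 2.2-fold higher number from compound 2 to compound 3 (0.34 log units; beyond the scatter) is modest but beyond the scatter, and the step of a 1.6-fold lower number from compound 1 to compound 2 (0.22 log units; within the scatter) stays within the scatter. All three compounds therefore sit within a narrow band.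

Compound 4 `CCOC(=O)c1c(CSc2cc(C)cc(C)c2)n(C)c2ccc(O)cc12` differs from compound 3 in one place: 3,5-dimethylphenyl in place of 2,4-difluorophenyl on a sulfur. Among the compounds with values here, no measured step exchanges a fluorinated aryl group for a methylated one, so the only guidance is the general picture that changing the aryl group on the sulfur, among compounds 1, 2 and 3, moves this assay by little: at most the modest step from compound 2 to compound 3, and otherwise within the scatter.

On that basis compound 4 is expected to show a step of about a 1.4-fold lower number from compound 3 to compound 4 (0.13 log units; within the scatter), most likely no change beyond the scatter, with a slight lean toward a lower number given that compound 3 holds the highest value. Compound 4 is estimated at 5000 nM, with a range from 2000 nM to 12000 nM.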

Compound 4, half-maximal inhibitory concentration: 2700 nM
The estimate for compound 4 lay 1.9-fold (0.27 log units) above the measured number; measured number inside the range.
By their numbers in this assay, from the lowest: compounds 4, 2, 1 and 3 (each within the scatter of the next, the first and the last beyond it).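

Exchanging 2,4-difluorophenyl for 3,5-dimethylphenyl on the sulfur gives a 2.5-fold lower number from compound 3 to compound 4 (0.40 log units; beyond the scatter) in this assay as the largest step yet seen at this position, and it is still modest. Set against the two methoxyphenyl groups, the new group brings no change that can be told: a 1.1-fold lower number from compound 2 to compound 4 (0.06 log units; within the scatter) and a 1.9-fold lower number from compound 1 to compound 4 (0.28 log units; within the scatter) both stay within the scatter. Both 3,5-dimethylphenyl and 4-methoxyphenyl now stand beyond the scatter from 2,4-difluorophenyl while 2-methoxyphenyl does not, and nothing at hand explains this small separation.

The compounds shown leave open whether any group on this sulfur can move the number well outside this narrow band, since all four carry a substituted phenyl ring. A pyridine ring, a cyclohexyl ring or a simple alkyl chain in place of the phenyl ring, or an amine or a carboxylic acid on that ring, would test how far this position really tolerates change.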